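Swapping Methoxy for Chloro at the Far End

The compounds below may be only part of what the source reports. "The series", "measured", "known", "first", "only" and "open" are said of these compounds alone.

Two compounds share one core. Compound 1 `COc1cccc(N2CCN(CC(=O)N3CCN(c4nnc(-c5ccccc5)c(-c5ccccc5)n4)CC3)CC2)c1` carries a 3-methoxyphenyl on an amine nitrogen in a ring, and in an ADME assay on NIH3T3 cells (Mus musculus) for cytotoxicity, read by MTT assay, with a stated time of 24 h (a lower number here means a stronger inhibitor, a higher number a weaker inhibitor), compound 1 gives 361000 nM. Compound 2 `COc1ccc(N2CCN(CC(=O)N3CCN(c4nnc(-c5ccccc5)c(-c5ccccc5)n4)CC3)CC2)cc1` carries a 4-methoxyphenyl in that place. In this assay compound 2 gives > 910000 nM, which is a limit of the assay rather than a number. For the measured compounds named here, the one measured step, an at least 2.5-fold higher number from compound 1 to compound 2 (0.40 log units; beyond the scatter), rests on that limit (the limit of > 910000 nM in this assay, at which 1 of the 2 values shown sits), so only its lower bound is known. Compound 2 thus stands at the weak end of what has been measured.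

Compound 3 `O=C(CN1CCN(c2ccc(Cl)cc2)CC1)N1CCN(c2nnc(-c3ccccc3)c(-c3ccccc3)n2)CC1` differs from compound 2 by chloro in place of methoxy on an aromatic carbon. Going by the values given here, no measured step exchanges methoxy for chloro; the single step available shifts a methoxy around the same ring and already reaches the limit, so it bears on this change only indirectly. The step expected, an at least 1.1-fold lower number from compound 2 to compound 3 (0.05 log units; that floor lies within the scatter), is none beyond the scatter. Compound 3 is expected to give about 800000 nM in this assay, between 300000 nM and 2500000 nM, with a fair chance that only a limit is reported again.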

Compound 3, half-maximal inhibitory concentration: 113000 nM
Estimate against measurement, compound 3: 7.1-fold (0.85 log units) above; measured number outside the range, below it.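

In this assay, for the compounds shown here, the earlier compounds showed only that moving a methoxy around the ring changes the number, and this result shows that the group itself matters as well: with 4-chlorophenyl in place of 4-methoxyphenyl, the change is an at least 8.0-fold lower number from compound 2 to compound 3 (0.90 log units; beyond the scatter). From the compounds shown here alone, the true size of that step is unknown and only its lower bound can be read, since compound 2 stands at a limit of the assay and not at a number: the limit of > 910000 nM in this assay, at which 1 of the 3 values shown sits. The comparison with the other methoxy compound needs no limit, and it gives a 3.2-fold lower number from compound 1 to compound 3 (0.50 log units; beyond the scatter), which leaves compound 3 with the lowest number of the three, and so the strongest effect on these cells.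

The compounds shown leave open whether this drop belongs to chloro alone or would also appear with another group at this place, such as fluoro, bromo, methyl or an amine, and whether chloro would act the same way where the methoxy sits in compound 1. They also hold no measured property that could explain why the number falls, so the cause of the change remains unknown.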